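A few compounds are considered here, and "the series" means these few. Any claim that something is new, unique, unknown or untested is made for them only; others in the source may bear on it.

Within the data shown here, compound 2 `COc1ccc(C2=NN(C(=O)CO[N+](=O)[O-])C(c3c(Cl)cccc3Cl)C2)cc1OC` stands lowest of the two numbers so far obtained in a functional assay on the whole organism (strain albino) for inhibition, with Rattus norvegicus as the target, read by paw edema, with stated times of 30 min and 1 h, at a dose of 100 mg/kg by the oral route; on this read-out higher numbers stand for more inhibition at the one dose given (going by the name of the read-out) and lower numbers for less inhibition: in this assay compound 2 gives 40%. Among the measured compounds shown here, its nearest neighbour is compound 1 `COc1ccc(C2=NNC(c3c(Cl)cccc3Cl)C2)cc1`, which in this assay gives 54%, a number higher than that of compound 2 by more than the usual scatter; these two compounds differ in more than one place, so no single step links them. Compound 3 `COc1ccc(C2=NN(C(=O)CO[N+](=O)[O-])C(c3c(Cl)cccc3Cl)C2)cc1` has not yet been measured. It differs from compound 2 in one place: hydrogen in place of methoxy on an aromatic carbon. For the measured compounds named here, no measured pair shows this change on its own. Compound 3 shares the 4-methoxyphenyl group with compound 1, whose value is 54%, but differs from it elsewhere, so only a cautious expectation is possible. The expected step is a number 7 percentage points higher from compound 2 to compound 3 (within the scatter), a small rise that may well stay within the scatter. Compound 3 is expected to give 47%, with a range from 34% to 60%.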

Compound 3, a percentage reported as inhibition, in the whole organism at one dose (the size of the read-out at that dose, not a potency): 34%
Beside the measured number, compound 3's estimate is 13 percentage points above it; low and high end bracket the measured number.
By their numbers in this assay, from the lowest: compounds 3 and 2 (each within the scatter of the next); then compound 1.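

In this assay, hydrogen in place of methoxy, the change from 3,4-dimethoxyphenyl to 4-methoxyphenyl, gives a number 6 percentage points lower from compound 2 to compound 3 (within the scatter), so on this aromatic carbon, ortho to a methoxy group, the exchange leaves no reading beyond the scatter. Among these compounds, the new compound also gives the first single-place comparison for the ring amine nitrogen: ((nitrooxy)methyl)carbonyl in place of hydrogen gives a number 20 percentage points lower from compound 1 to compound 3 (beyond the scatter), a drop seen in this one pair only. Nothing at hand bears on the reason for either result.

The compounds shown leave open whether a fluorine or a hydroxy group on that aromatic carbon would read differently from methoxy or hydrogen. They also leave open whether a plain acetyl group or a longer chain carrying the nitrooxy group on the ring nitrogen would give the same drop.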